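Chloro in place of hydrogen on the benzyl ring of compound 3

A few compounds are considered here, and "the series" means these few. Any claim that something is new, unique, unknown or untested is made for them only; others in the source may bear on it.

Three measured compounds share one core and a benzylsulfanyl arm. Compound 1 `O=S(=O)(Nc1nnc(SCc2ccc(Cl)cc2)s1)c1ccccc1` gives 85% in a functional assay on MCF7 cells (Homo sapiens) for cytotoxicity, tested at 125 uM; a lower number here means a stronger effect, a higher number a weaker effect of the compound at the concentration tested. Compound 2 `Cc1ccc(S(=O)(=O)Nc2nnc(SCc3ccc(Cl)cc3)s2)cc1` gives 82% in this assay; the step of a number 3 percentage points lower from compound 1 to compound 2 (within the scatter) lies within the scatter. Compound 3 `Cc1cc(C)c(S(=O)(=O)Nc2nnc(SCc3ccccc3)s2)c(C)c1` gives 75% in this assay, the lowest number of the three, but its gap to compound 2 and its gap to compound 1 both lie within the scatter, so no order among the three compounds can be read from these numbers.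

Compound 4 `Cc1cc(C)c(S(=O)(=O)Nc2nnc(SCc3ccc(Cl)cc3)s2)c(C)c1` differs from compound 3 in one place: chloro in place of hydrogen on an aromatic carbon. Among the compounds with values here, no measured pair isolates this change; compound 1 and compound 2 already carry the chloro group, and the single measured step, a methyl change elsewhere, stayed within the scatter. No step beyond the scatter is therefore expected in this assay for this change. Compound 4 is expected to give about 74%, within a range from 62% to 86%. The expected step of a number 1 percentage points lower from compound 3 to compound 4 (within the scatter) stays within the scatter.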

Compound 4, a percentage reported as activity, at one concentration (the size of the read-out at that concentration, not a potency): 82%
Beside the measured number, compound 4's estimate is 8 percentage points below it; the range from low to high includes it.
By their numbers in this assay, from the lowest: compounds 3, 2, 4 and 1 (each within the scatter of the next).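

In this assay, within the data shown here, the step of a number 7 percentage points higher from compound 3 to compound 4 (within the scatter) gives the first direct reading of chloro in place of hydrogen on the benzyl ring, para to a large group, and the change shows no step beyond the scatter. With the 4-chlorobenzyl arm held constant, the step of no change at the digits printed from compound 2 to compound 4 (within the scatter) for 2,4,6-trimethylphenyl in place of 4-methylphenyl and the step of a number 3 percentage points lower from compound 1 to compound 4 (within the scatter) for 2,4,6-trimethylphenyl in place of phenyl also stay within the scatter. No measurement offers an explanation for these readings.

As far as these compounds go, whether an amine or a carboxylic acid at this ring position would give a step beyond the scatter remains open. The same question stands for a longer chain in place of the benzyl group.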